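Swapping the Aryl Amide for a Pyrrolidinylmethyl Amide

The source may report more compounds than this note shows. Statements on the series, on what has been measured and on what is new or still open speak of the compounds shown alone.

Of the compounds shown here, two have been measured in a functional assay on PC-3 cells (Homo sapiens) for cytotoxicity, read by MTT assay, with a stated time of 48 h; a higher number here means a weaker inhibitor, a lower number a stronger inhibitor. Compound 1 `CC1=NN(S(=O)(=O)c2ccc([N+](=O)[O-])cc2)C(c2cc(Cl)ccc2O)C1` gives 44200 nM. Compound 2 `Cc1ccc(C(=O)N2N=C(c3cc4ccccc4oc3=O)CC2c2ccccc2)cc1` gives 13200 nM, the lower of the two numbers, and its gap to compound 1 lies beyond the usual scatter of this assay.

Compound 3 `O=C(CN1CCCC1)N1N=C(c2cc3ccccc3oc2=O)CC1c1ccccc1` shares the core of compound 2 and differs in one place, on the carbonyl attached to the amide-type nitrogen in the ring: (pyrrolidin-1-yl)methyl in place of 4-methylphenyl on a carbonyl carbon. The difference, taken one bond further out, reads as (4-methylphenyl)carbonyl becoming ((pyrrolidin-1-yl)methyl)carbonyl.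

Going by the values given here, no measured pair in this set shows what such a change does, so the step has to be guessed from the single pair at hand, which says nothing about this position. The author expects the step from compound 2 to compound 3 to stay within the scatter, a 1.1-fold higher number from compound 2 to compound 3 (0.06 log units; within the scatter), with no strong lean in either direction. For compound 3 the estimate in this assay is 15000 nM, with a plausible range from 5000 nM to 45000 nM.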

Compound 3, half-maximal inhibitory concentration: 50200 nM
Beside the measured number, compound 3's estimate is 3.3-fold (0.52 log units) below it; the whole stated range lies below it.
By their numbers in this assay, from the lowest: compound 2; then compounds 1 and 3 (each within the scatter of the next).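

In this assay, the carbonyl carbon on the amide-type nitrogen in the ring proves sensitive to what it carries: (pyrrolidin-1-yl)methyl in place of 4-methylphenyl gives a 3.8-fold higher number from compound 2 to compound 3 (0.58 log units; beyond the scatter). Going by these compounds alone, this is the first measured step in the set, and on this shared core it favours 4-methylphenyl over (pyrrolidin-1-yl)methyl, with the lower number on the side of the six-membered aromatic ring of carbon only. The change also swaps that ring for a five-membered non-aromatic ring with 1 hetero atom and brings in 1 hydrogen-bond acceptor, and no measurement at hand bears on which of these differences accounts for the step.

The compounds shown leave open whether the number follows the loss of the aromatic ring or the arrival of the ring nitrogen, since the single step changes both at once. A cyclopentylmethyl group on the same carbonyl carbon, with its ring but no nitrogen, or a 4-(dimethylamino)phenyl group, with an amine kept on an aromatic ring, would pull those two apart.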